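Amide side chains on a shared core at the vitamin D receptor

The source may report more compounds than this note shows. Statements on the series, on what has been measured and on what is new or still open speak of the compounds shown alone.

Measured compounds:
compound 1, `CCOC(=O)CN(C)C(=O)c1ccc(C(CC)(CC)c2ccc(OCC(=O)C(C)(C)C)c(C)c2)n1CC`, > 50000 nM
compound 2, `CCN(CC)CCNC(=O)c1ccc(C(CC)(CC)c2ccc(OCC(=O)C(C)(C)C)c(C)c2)n1CC`, 91 nM
compound 3, `CCn1c(C(=O)NCC(OC)OC)ccc1C(CC)(CC)c1ccc(OCC(=O)C(C)(C)C)c(C)c1`, 130 nM

In an assay on HL-60 cells for agonist activity at vitamin D3 receptor (Homo sapiens), read by microscopy, with a stated time of 96 h (a higher number here means that more compound is needed for the effect, a lower number that less compound is needed), compound 1 reaches only a limit, (the limit of > 50000 nM in this assay, at which 1 of the 3 values shown sits). Compound 2 gives 91 nM in this assay, and compound 3 gives 130 nM; these two lie within the scatter of each other, a 1.4-fold higher number from compound 2 to compound 3 (0.15 log units; within the scatter). Compound 3 thus holds the higher of the two numbers given, with the limit of compound 1 beside them.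

Compound 4, `CCn1c(C(=O)NCCN)ccc1C(CC)(CC)c1ccc(OCC(=O)C(C)(C)C)c(C)c1`, differs from compound 3 in one place: aminomethyl in place of dimethoxymethyl on a saturated chain carbon bound to an amide-type nitrogen. Among the measured compounds shown here, the only measured step at this place is a 1.4-fold higher number from compound 2 to compound 3 (0.15 log units; within the scatter), which stayed within the scatter, so no change beyond the scatter is expected from compound 3 to compound 4, a 1.3-fold lower number from compound 3 to compound 4 (0.11 log units; within the scatter). Compound 4 is estimated at 100 nM, between 30 nM and 400 nM.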

Compound 4, half-maximal effective concentration: 120 nM
The estimate for compound 4 lay 1.2-fold (0.08 log units) below the measured number; low and high end bracket the measured number.
By their numbers in this assay, from the lowest: compounds 2, 4 and 3 (each within the scatter of the next). At a limit, above all of these: compound 1.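

The short 2-aminoethyl chain on the amide nitrogen fits with the two longer chains in this assay: there is a 1.1-fold lower number from compound 3 to compound 4 (0.03 log units; within the scatter), and a 1.3-fold higher number from compound 2 to compound 4 (0.12 log units; within the scatter), so the three end groups cannot be told apart here. The contrast with compound 1 holds for this chain too, with an at least 410-fold lower number from compound 1 to compound 4 (2.61 log units; beyond the scatter). Compound 1 remains a limit and not a number: the limit of > 50000 nM in this assay, at which 1 of the 4 values shown sits.

Going by these compounds, it stays open whether that gap goes with the ethoxycarbonyl group or with the methyl on the amide nitrogen. On these data alone, how a carboxylic acid at the chain end or a longer chain would read also stays open.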